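A few compounds are considered here, and "the series" means these few. Any claim that something is new, unique, unknown or untested is made for them only; others in the source may bear on it.

The measured compounds:

compound 1, `Cc1nc(C#Cc2cc(F)cc([N+](=O)[O-])c2)cs1`, with 0.61 nM in a functional assay on HEK293 cells for antagonist activity at metabotropic glutamate receptor 5 (Rattus norvegicus), read by calcium flux; a lower number here means a stronger inhibitor, a higher number a weaker inhibitor
compound 2, `Cc1nc(C#Cc2cc(I)cc([N+](=O)[O-])c2)cs1`, with 1.75 nM in this assay
compound 3, `Cc1cccc(C#Cc2cc(F)cc(C#N)c2)n1`, with 1.22 nM in this assay

Compound 1 and compound 2 share one core and differ in a single place: iodo in place of fluoro on an aromatic carbon. That change gave a 2.9-fold higher number from compound 1 to compound 2 (0.46 log units; beyond the scatter). Compound 3 carries a different core; how the core of compound 3 differs from the core of compound 1 is not broken down here. Its value in this assay lies within the scatter of both compound 1 and compound 2, so no order among the three is claimed.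

Compound 4, `Cc1cccc(C#Cc2cc(I)cc(C#N)c2)n1`, is not yet measured in this assay. It stands to compound 3 as compound 2 stands to compound 1: iodo in place of fluoro on an aromatic carbon. The surroundings of the place are not identical, however. In compound 1 the carbon sits meta to a group of 8 heavy atoms and meta to a nitro group (3 heavy atoms); in compound 3 it sits meta to a cyano group (2 heavy atoms) and meta to a group of 9 heavy atoms. The change is therefore the same kind of change, not the same change, and it occurs twice among the compounds shown.

Among the compounds with values here, with only one earlier instance to go on, the expectation for compound 4 rests on compound 1 and compound 2, whose step was a 2.9-fold higher number from compound 1 to compound 2 (0.46 log units; beyond the scatter), and a step of about a 2.9-fold higher number from compound 3 to compound 4 (0.46 log units; beyond the scatter) is estimated from compound 3 to compound 4. Compound 4 is thus expected to give 3.5 nM in this assay, most likely between 1.5 nM and 8 nM.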

Compound 4, half-maximal inhibitory concentration: 0.71 nM
Beside the measured number, compound 4's estimate is 4.9-fold (0.69 log units) above it, and the stated range ends above it.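

On the core of compound 3, in this assay, iodo in place of fluoro gave a 1.7-fold lower number from compound 3 to compound 4 (0.24 log units; within the scatter), so this step shows no clear change in either direction. Set beside the earlier instance, the two results do not agree: the same change on two cores in this assay, a 2.9-fold higher number (0.46 log units; beyond the scatter) from compound 1 to compound 2 and a 1.7-fold lower number (0.24 log units; within the scatter) from compound 3 to compound 4, 4.9-fold (0.69 log units) apart, beyond the scatter of two such steps. Within the data shown here, this shows that, in this series, the step measured on the core of compound 1 cannot be carried to the core of compound 3 as a fixed amount, but with only two pairs it does not show which difference between the cores goes with the divergence, nor how the change would behave on any further core.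

The compounds shown pair the nitro group only with the group of 8 heavy atoms and the cyano group only with the group of 9 heavy atoms, which leaves open whether the divergence follows one of these parts, the other or both together. Also open, going by these compounds, is how a chloro group, a bromo group or an amine at the same place would read on either core, and whether such groups would follow the pattern of the fluoro and iodo pairs at all.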